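A Pyridin-4-ylmethyl Amine Analogue and Cell Tolerance

The source may hold more compounds than are shown below. What is called first, only, known or untested is meant among the compounds shown, and "the series" means these compounds.

Compound 1 `Cc1ccccc1-c1nn(-c2ccc(F)cc2F)cc1CNC1CCN(S(C)(=O)=O)CC1` gives in an ADME assay on Huh-7 cells (Homo sapiens) for cytotoxicity; a higher number here means that more compound is tolerated, a lower number that less compound is tolerated > 20000 nM, which is a limit of the assay rather than a number.
Compound 2 `CN1CCN(CCNCc2cn(-c3ccc([N+](=O)[O-])cc3)nc2-c2ccc(OC(F)(F)F)cc2)CC1` gives in this assay 4400 nM.
Compound 3 `Cc1ccc(-c2nn(-c3ccc(F)cc3F)cc2CNCCN2CCN(C)CC2)cc1` gives in this assay > 20000 nM, again a limit of the assay and not a number.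

Compound 1 therefore stands at the top of what this assay can report, at the limit of > 20000 nM in this assay, at which 2 of the 3 values shown sit. Within the data shown here, no step between two measured compounds has been worked out here, so the values of compound 2 and compound 3 can only be set beside it: compound 2 returns a number, while compound 3 sits at the same limit as compound 1.

Compound 4 `Cc1ccccc1-c1nn(-c2ccc(F)cc2F)cc1CNCc1ccncc1` is compound 1 with a single change: (pyridin-4-yl)methyl in place of 1-(methylsulfonyl)piperidin-4-yl on an amine nitrogen. The shared core is otherwise kept. Among the measured compounds shown here, with no measured step to lean on, the expectation rests on compound 1 alone, and because compound 1 reports > 20000 nM the change is expected to move the reading by no more than the scatter, in no particular direction. Compound 4 is therefore expected to give 20000 nM, within a range from 8000 nM to 40000 nM. The step this estimate implies is a number no higher from compound 1 to compound 4 (the limit leaves the size open), expected to stay within the usual scatter.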

Compound 4, half-maximal cytotoxic concentration: > 20000 nM
Compound 4 was reported as a limit (the forecaster's own chance of this, stated with the estimate: 60%); the middle value sits exactly at the limit.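

Compound 1 and compound 4 both report a limit of the assay rather than a number, so no step between them can be read: the limit of > 20000 nM in this assay, at which 3 of the 4 values shown sit.

The compounds shown leave open whether (pyridin-4-yl)methyl in place of 1-(methylsulfonyl)piperidin-4-yl changes the reading in this assay at all.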